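The source may report more compounds than this note shows. Statements on the series, on what has been measured and on what is new or still open speak of the compounds shown alone.

Of the compounds shown here, three built on one shared core have been measured in a functional assay on MGC-803 cells (Homo sapiens) for antiproliferative activity, read by MTT assay, with a stated time of 48 h; a higher number here means a weaker inhibitor, a lower number a stronger inhibitor. Compound 1 `O=C(Nc1ccc(Cl)cc1)Nc1cccc(CNc2nccnc2Cl)c1` gives 4980 nM, compound 2 `CC(C)(C)c1ccc(NC(=O)Nc2cccc(CNc3nccnc3Cl)c2)cc1` gives 4820 nM, and compound 3 `O=C(Nc1ccc(C(F)(F)F)cc1)Nc1cccc(CNc2nccnc2Cl)c1` gives 6910 nM. Compound 1 thus stands second highest of the three, nearest to compound 2 and furthest from compound 3. Every measured step is small: a 1.0-fold lower number from compound 1 to compound 2 (0.01 log units; within the scatter), a 1.4-fold higher number from compound 1 to compound 3 (0.14 log units; within the scatter) and a 1.4-fold higher number from compound 2 to compound 3 (0.16 log units; within the scatter). Compound 4 `Cc1cccc(NC(=O)Nc2cccc(CNc3nccnc3Cl)c2)c1` differs from compound 1 by 3-methylphenyl in place of 4-chlorophenyl on an amide-type nitrogen. Among the compounds with values here, no measured step covers this exact exchange, but the three steps each swap one group on an aromatic carbon of the same part and all stay within the scatter. The expected step is therefore a 1.0-fold higher number from compound 1 to compound 4 (0.00 log units; within the scatter), nothing beyond the scatter in this assay. Compound 4 is estimated at 5000 nM, between 2500 nM and 10000 nM.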

Compound 4, half-maximal inhibitory concentration: 14600 nM
Compound 4: the middle estimate sits 2.9-fold (0.47 log units) below what was measured; the whole stated range lies below it.
By their numbers in this assay, from the lowest: compounds 2, 1 and 3 (each within the scatter of the next); then compound 4.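

Within the data shown here, replacing 4-chlorophenyl with 3-methylphenyl on the amide-type nitrogen gives a 2.9-fold higher number from compound 1 to compound 4 (0.47 log units; beyond the scatter) and so is the first step to pass beyond the scatter. The swaps among chloro, tert-butyl and trifluoromethyl all stayed within the scatter, so this part of the molecule does not tolerate every exchange equally. No measurement shown here accounts for this step. The compounds shown leave open whether the shift follows the methyl group or its place on the ring. 4-Methylphenyl and 3-chlorophenyl would separate these two readings.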